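Phenylsulfonyl on the Ring Amine and Liver Cell Cytotoxicity

The source may report more compounds than this note shows. Statements on the series, on what has been measured and on what is new or still open speak of the compounds shown alone.

Compound 1 `O=C1/C(=C/c2cccnc2)CNC/C1=C\c1ccccc1F` was examined in an ADME assay on L02 cells (Homo sapiens) for cytotoxicity, read by MTT assay, with a stated time of 24 h (on this read-out lower numbers stand for stronger inhibition and higher numbers for weaker inhibition), where compound 1 gives 15900 nM. Compound 2 `O=C1/C(=C/c2cccnc2)CN(S(=O)(=O)c2ccccc2)C/C1=C\c1ccccc1F` carries the change (phenylsulfonyl in place of hydrogen on an amine nitrogen in a ring); in this assay compound 2 gives 15300 nM, a step of a 1.0-fold lower number from compound 1 to compound 2 (0.02 log units; within the scatter). Compound 3 `O=C1/C(=C/c2cccnc2)CNC/C1=C\c1ccccc1C(F)(F)F` differs from compound 1 in its core by trifluoromethyl in place of fluoro on an aromatic carbon, and in this assay compound 3 gives 11300 nM, which amounts to a 1.4-fold lower number from compound 1 to compound 3 (0.15 log units; within the scatter). Compound 4 `O=C1/C(=C/c2cccnc2)CN(S(=O)(=O)c2ccccc2)C/C1=C\c1ccccc1C(F)(F)F` has not yet been measured; it differs from compound 3 by phenylsulfonyl in place of hydrogen on an amine nitrogen in a ring, the same change that leads from compound 1 to compound 2, at a place described in identical words. In this assay the expected step is a 1.0-fold lower number from compound 3 to compound 4 (0.01 log units; within the scatter), resting on the earlier step of a 1.0-fold lower number from compound 1 to compound 2 (0.02 log units; within the scatter). Compound 4 is therefore estimated at 11000 nM, with a likely range from 5000 nM to 25000 nM.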

Compound 4, half-maximal inhibitory concentration: 12500 nM
For compound 4 the middle estimate is 1.1-fold (0.06 log units) below the measured one; the measured number falls inside the stated range.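

In this assay, phenylsulfonyl on the ring amine gives a 1.1-fold higher number from compound 3 to compound 4 (0.04 log units; within the scatter), which agrees with the earlier step on the core of compound 1: the same change on two cores in this assay, a 1.0-fold lower number (0.02 log units; within the scatter) from compound 1 to compound 2 and a 1.1-fold higher number (0.04 log units; within the scatter) from compound 3 to compound 4, 1.1-fold (0.06 log units) apart, within the scatter of two such steps. Trifluoromethyl in place of fluoro gives a 1.2-fold lower number from compound 2 to compound 4 (0.09 log units; within the scatter), and this change also carries across the two cores: the same change on two cores in this assay, a 1.4-fold lower number (0.15 log units; within the scatter) from compound 1 to compound 3 and a 1.2-fold lower number (0.09 log units; within the scatter) from compound 2 to compound 4, 1.1-fold (0.06 log units) apart, within the scatter of two such steps. Within the data shown here, since every one of these steps lies within the scatter, the four compounds show only that neither change moved the number detectably on these two cores, and they do not show that either change has an effect of its own or would behave alike on any other core.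

Still open, from the compounds shown here alone, is whether a different group on the ring amine, such as an acetyl group or a longer alkyl chain, would shift the number beyond the scatter. The same question stands for an amine or a carboxylic acid on the aromatic ring of the phenylsulfonyl group.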